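Turning the double bond of compound 3 from E to Z

The source may report more compounds than this note shows. Statements on the series, on what has been measured and on what is new or still open speak of the compounds shown alone.

Compound 3, `CC1(C)CCC(C)(C)c2cc(/C=C/c3cccc(N)c3)ccc21`, carries the lowest number of the three compounds measured in a functional assay on HL-60 cells (Homo sapiens) for cytotoxicity; a lower number here means a stronger inhibitor, a higher number a weaker inhibitor: compound 3 gives 20000 nM. Compound 2, `COc1ccc(/C=C/c2ccc3c(c2)C(C)(C)CCC3(C)C)cc1`, gives 50000 nM, and compound 1, `COc1ccc(/C=C/c2ccc3c(c2)C(C)(C)CCC3(C)C)cc1N`, gives 61000 nM. The step from compound 1 to compound 2, swapping hydrogen for amino on an aromatic carbon, was a 1.2-fold lower number from compound 1 to compound 2 (0.09 log units; within the scatter). The step of a 3.1-fold lower number from compound 1 to compound 3 (0.48 log units; beyond the scatter) put hydrogen in place of methoxy, and the step of a 2.5-fold lower number from compound 2 to compound 3 (0.40 log units; beyond the scatter) put 3-aminophenyl in place of 4-methoxyphenyl; both were modest and beyond the scatter.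

Compound 4, `CC1(C)CCC(C)(C)c2cc(/C=C\c3cccc(N)c3)ccc21`, differs from compound 3 only as the two compounds have the same atoms and bonds and differ only in configuration as drawn: 1 of 1 stereo elements differ; a double bond is drawn E in compound 3 and Z in compound 4. None of the three measured steps changes the geometry of the double bond, so they give no direct guide to this change. The expectation is therefore a step of a 1.5-fold higher number from compound 3 to compound 4 (0.18 log units; within the scatter), close to none beyond the scatter, with a wide margin of doubt. Compound 4 is estimated to give 30000 nM in this assay, within a range from 7000 nM to 130000 nM.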

Compound 4, half-maximal inhibitory concentration: 10000 nM
For compound 4 the middle estimate is 3.0-fold (0.48 log units) above the measured one, within the range that was stated.
By their numbers in this assay, from the lowest: compounds 4 and 3 (each within the scatter of the next); then compounds 2 and 1 (each within the scatter of the next).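

In this assay, turning the double bond from E to Z gave a 2.0-fold lower number from compound 3 to compound 4 (0.30 log units; within the scatter), so the geometry of this double bond makes no difference that can be told from the scatter. The earlier steps shown here all kept the E double bond and exchanged groups on the aromatic ring, so they could not show this; here, a Z double bond keeps compound 4 level with compound 3. The comparison is a clean one, with a single change to read: the fact that compounds 3 and 4 differ only in the configuration as drawn.

The compounds shown leave open whether the Z double bond would behave the same way with the 4-methoxyphenyl group of compound 2, or with the amino and methoxy groups together as in compound 1. From the compounds shown here alone, it also remains open how a carboxylic acid in place of the amino group would fare with either geometry.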